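Swapping the Phenyl Group from Compound 2 to Compound 3

A few compounds are considered here, and "the series" means these few. Any claim that something is new, unique, unknown or untested is made for them only; others in the source may bear on it.

Measured so far:
Compound 1 `CC1=CC[C@H](C(C)(C)N=C=S)CC1`: in a functional assay on U-251 cells (Homo sapiens) for inhibition, read by sulforhodamine B assay, with a stated time of 48 h (a higher number here means a weaker inhibitor of growth, a lower number a stronger inhibitor of growth), compound 1 reaches only a limit, > 100000 nM.
Compound 2 `COc1ccc(/C=N/NC(=S)NC(C)(C)[C@H]2CC=C(C)CC2)cc1`: in this assay compound 2 gives 71900 nM.

For the measured compounds named here, compound 2 holds the only numeric value shown. Compound 1 sits at the limit of the assay, (the limit of > 100000 nM in this assay, at which 1 of the 2 values shown sits), and says no more than that.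

Compound 3 `CC1=CC[C@H](C(C)(C)NC(=S)N/N=C/c2ccccc2Cl)CC1` differs from compound 2 in one place: 2-chlorophenyl in place of 4-methoxyphenyl on a carbon with a double bond to nitrogen. Going by the values given here, no measured pair separates such a change, so no step beyond the scatter is expected in either direction. Compound 3 is therefore estimated at 60000 nM, between 20000 nM and 200000 nM, a step of a 1.2-fold lower number from compound 2 to compound 3 (0.08 log units; within the scatter) expected to stay within the scatter.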

Compound 3, concentration for total growth inhibition: > 100000 nM
Compound 3 was reported as a limit; the forecaster's own chance of this, stated with the estimate: 30%; at least 1.6-fold (0.22 log units) between middle value and limit.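

In this assay compound 3 gives > 100000 nM, which is a limit of the assay and not a number. With 2-chlorophenyl in place of 4-methoxyphenyl on a carbon with a double bond to nitrogen, the result is an at least 1.3-fold higher number from compound 2 to compound 3 (0.14 log units; that floor lies within the scatter), so this change is not shown to shift growth inhibition beyond the scatter. The numeric reading at this position is not kept, and the assay limit now covers most of the compounds: the limit of > 100000 nM in this assay, at which 2 of the 3 values shown sit.

As far as these compounds go, how far compound 3 lies past its limit remains open. So does what an amine or a carboxylic acid on this aromatic ring would give.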